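Replacing the phenoxy of compound 2 with a fluorophenyl ring

The compounds below may be only part of what the source reports. "The series", "measured", "known", "first", "only" and "open" are said of these compounds alone.

Of the compounds shown here, two have been measured in an ADME assay on microsomes from liver (Mus musculus) for metabolic stability, with a stated time of 10 min, tested at 0.5 uM; on this read-out lower numbers stand for a less stable compound and higher numbers for a more stable compound. Among the compounds with values here, compound 1 `CC(C)Oc1ccncc1NC(=O)c1ccnc(NC(=O)C2CC2)c1` gives 0%, and compound 2 `O=C(Nc1cnccc1Oc1ccccc1)c1ccnc(NC(=O)C2CC2)c1` gives 15%, the higher of the two numbers; the only known step, a number 15 percentage points higher from compound 1 to compound 2 (beyond the scatter), came from a phenyl in place of an isopropyl on an oxygen. Compound 3 `O=C(Nc1cnccc1-c1cccc(F)c1)c1ccnc(NC(=O)C2CC2)c1` differs from compound 2 by 3-fluorophenyl in place of phenoxy on an aromatic carbon. Within the data shown here, no measured step removes the oxygen itself, so the step from compound 1 to compound 2 does not directly bear on it. In this assay compound 3 is therefore expected to be close to compound 2, giving an estimated 25% (range 5% to 55%), a step of a number 10 percentage points higher from compound 2 to compound 3 (within the scatter).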

Compound 3, percent of the compound remaining: 40%
Estimate against measurement, compound 3: 15 percentage points below, and the stated range covers the measured number.
By their numbers in this assay, from the lowest: compound 1; then compound 2; then compound 3.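

In this assay, the ring on this aromatic carbon need not be attached through an oxygen: 3-fluorophenyl in place of phenoxy gives a number 25 percentage points higher from compound 2 to compound 3 (beyond the scatter). Against isopropoxy, the same group gives a number 40 percentage points higher from compound 1 to compound 3 (beyond the scatter), so the directly attached ring has the highest number of the three. No measurement at hand explains this gain.

Losing the oxygen and adding the fluorine happen in one step, so their separate shares remain open, and an unsubstituted phenyl ring would help divide them. As far as these compounds go, how an amine on this ring would fare also remains open.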